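This account rests on a few compounds, and the source may have more. Where it says the series, first, only, none or still open, it means among the compounds named here.

Compound 1, `CC(=O)N[C@@H]1CCC[C@H](C(=O)Nc2cc(-c3cnn4c3CCCC4)c(Cl)cn2)C1`: in an ADME assay on cells (Hepatocyte, Homo sapiens) for metabolic stability, using equilibrium dialysis (on this read-out lower numbers stand for slow clearance and higher numbers for fast clearance), compound 1 gives < 1.2 uL/min, which is a limit of the assay.
Compound 2, `CC(=O)N[C@@H]1CCC[C@H](C(=O)Nc2cc(-c3cnn(C)c3C)c(Cl)cn2)C1`: in this assay compound 2 gives < 1 uL/min, which is also a limit of the assay.

For the measured compounds named here, compound 2 thus stands at a limit (the limit of < 1 uL/min in this assay, at which 1 of the 2 values shown sits), and the one other value shown is likewise a limit (the limit of < 1.2 uL/min in this assay, at which 1 of the 2 values shown sits). Compound 3, `CC(=O)N[C@@H]1CCC[C@H](C(=O)Nc2cc(-c3cnn4c3CCCCC4)c(Cl)cn2)C1`, differs from compound 2 by a group of 10 heavy atoms (8 carbon, 2 nitrogen; one five-membered aromatic ring with 2 hetero atoms, one seven-membered non-aromatic ring with 1 hetero atom) in place of a group of 7 heavy atoms (5 carbon, 2 nitrogen; one five-membered aromatic ring with 2 hetero atoms), on an aromatic carbon. Going by the values given here, the only measured step, a step that the two limits leave unreadable from compound 1 to compound 2, cannot be read. No step beyond the scatter is therefore expected in this assay for compound 3, with a number no lower from compound 2 to compound 3 (the limit leaves the size open) as the estimated step. Compound 3 is expected to give about 1 uL/min, between 0.5 uL/min and 3 uL/min, most likely again reported only as a limit.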

Compound 3, intrinsic clearance in a liver preparation (reported as CLH), per the amount of preparation that the assay uses: 4.6 uL/min
The estimate for compound 3 lay 4.6-fold (0.66 log units) below the measured number; measured number above the stated range.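

In this assay, the group on the aromatic carbon opposite the ring nitrogen now proves able to move the read-out, with an at least 4.6-fold higher number from compound 2 to compound 3 (0.66 log units; beyond the scatter). One further ring size also counts, with an at least 3.8-fold higher number from compound 1 to compound 3 (0.58 log units; beyond the scatter), so the seven-membered non-aromatic ring is set apart from the six-membered one. The step between compound 1 and compound 2 cannot be read.

From the compounds shown here alone, the true size of the step to compound 3 stays open because compound 2 stands at a limit: the limit of < 1 uL/min in this assay, at which 1 of the 3 values shown sits. Also open is how an amine on the seven-membered ring, or an eight-membered non-aromatic ring in its place, would read in this assay.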